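The source may hold more compounds than are shown below. What is called first, only, known or untested is meant among the compounds shown, and "the series" means these compounds.

Compound 3 `COc1cc(OC)cc(C(=O)NCCNC(=O)[C@H](CC(=O)NC(C)(C)C)NS(=O)(=O)c2ccc(C)cc2)c1` carries a 3,5-dimethoxyphenyl on a carbonyl carbon. In an ADME assay on Karpas-1106P cells (Homo sapiens) for cytotoxicity (a higher number here means that more compound is needed for the effect, a lower number that less compound is needed), compound 3 gives only a limit, > 11100 nM. Compound 1 `Cc1ccc(S(=O)(=O)N[C@@H](CC(=O)NC(C)(C)C)C(=O)NCCNC(=O)c2ccccc2)cc1`, with phenyl at that place, also gives only a limit in this assay, > 11100 nM. Compound 2 `Cc1ccc(S(=O)(=O)N[C@@H](CC(=O)NC(C)(C)C)C(=O)NCCNC(=O)Nc2ccccc2)cc1`, with anilino there, again reaches only a limit in this assay, > 11100 nM. The steps a step that the two limits leave unreadable from compound 1 to compound 3 and a step that the two limits leave unreadable from compound 2 to compound 3 stay unreadable because of the limit of > 11100 nM in this assay, at which 3 of the 3 values shown sit. Compound 4 `Cc1ccc(S(=O)(=O)N[C@@H](CC(=O)NC(C)(C)C)C(=O)NCCNC(=O)c2ccc(F)c(F)c2)cc1` differs from compound 3 by 3,4-difluorophenyl in place of 3,5-dimethoxyphenyl on a carbonyl carbon. Since every variation at this carbonyl carbon so far ends at the same limit, no step beyond the scatter is expected in this assay, and a step that the limit leaves unreadable from compound 3 to compound 4 is the estimated step. Compound 4 is thus expected near 15000 nM, within 5000 nM to 50000 nM, most probably reported once more as a limit.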

Compound 4, half-maximal effective concentration: > 11100 nM
Compound 4 gave a limit, no number; the forecaster's own chance of this, stated with the estimate: 85%; the middle value is on the limit's open side.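

Compound 4 ends like compounds 1, 2 and 3, so no step among them can be read in this assay: the limit of > 11100 nM in this assay, at which 4 of the 4 values shown sit.

The compounds shown leave open whether any variation at this carbonyl carbon changes the cytotoxicity.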